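The source may report more compounds than this note shows. Statements on the series, on what has been measured and on what is new or still open speak of the compounds shown alone.

In a functional assay on KBVIN cells (Homo sapiens) for antiproliferative activity, read by sulforhodamine B assay, with a stated time of 3 days (a higher number here means that more compound is needed for the effect, a lower number that less compound is needed), compound 1 (`CCC1=C(O)c2c(oc(-c3ccc(O)cc3)cc2=O)C(CC)(CC)C1=O`) gives 20.6 uM and compound 2 (`CCC1=C(O)c2c(oc(-c3ccc(OC)c(F)c3)cc2=O)C(CC)(CC)C1=O`) gives 0.1 uM as the lower of the two numbers. Compound 3 (`CCC1=C(O)c2c(oc(-c3cc(C)ccc3F)cc2=O)C(CC)(CC)C1=O`) has 2-fluoro-5-methylphenyl in place of 3-fluoro-4-methoxyphenyl (2-fluoro-5-methylphenyl in place of 3-fluoro-4-methoxyphenyl on an aromatic carbon) on the same aromatic carbon. Within the data shown here, the one measured step (a 210-fold lower number from compound 1 to compound 2 (2.31 log units; beyond the scatter)) changed the group at that carbon and was large, so a change there can move this assay strongly, though that step does not settle the direction for the new group. A moderately higher number is expected, and the estimated change is a 4.0-fold higher number from compound 2 to compound 3 (0.60 log units; beyond the scatter) with wide uncertainty. Compound 3 is estimated at 0.4 uM (expected range 0.08 uM to 2.5 uM).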

Compound 3, concentration for half-maximal effect: 3.24 uM
The estimate for compound 3 lay 8.1-fold (0.91 log units) below the measured number; measured number outside the range, above it.
By their numbers in this assay, from the lowest: compound 2; then compound 3; then compound 1.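

In this assay this position proved sensitive even between two fluorinated phenyl groups: 2-fluoro-5-methylphenyl in place of 3-fluoro-4-methoxyphenyl gave a 32-fold higher number from compound 2 to compound 3 (1.51 log units; beyond the scatter) and lost much of the earlier gain. The same group still stood ahead of 4-hydroxyphenyl, with a 6.4-fold lower number from compound 1 to compound 3 (0.80 log units; beyond the scatter) as the remaining difference. Nothing measured here explains either step. The compounds shown leave open whether the methoxy group, the methyl group or the place of the fluorine carries the difference, as these change together. Going by these compounds, how an amine or a carboxylic acid on this phenyl ring would behave also stays open.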